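Working notes: the step from compound 3 to compound 4

This account rests on a few compounds, and the source may have more. Where it says the series, first, only, none or still open, it means among the compounds named here.

Values in a functional assay on A549 cells (Homo sapiens) for cytotoxicity, with a stated time of 48 h (a higher number here means a weaker inhibitor, a lower number a stronger inhibitor), for the measured compounds:
- compound 1 `CCOc1ccc2oc(/C=C/[S+](C)[O-])cc(=O)c2c1` gives 1500 nM in this series
- compound 2 `C[S+]([O-])/C=C/c1cc(=O)c2ccccc2o1` gives 1900 nM in this series
- compound 3 `Cc1ccc2oc(/C=C/[S+](C)[O-])cc(=O)c2c1` gives 1700 nM in this series

Compound 3 lies within the scatter of both other compounds, so the three values form one level and give no order. Compound 4 `CCCCC(=O)Oc1ccc2oc(/C=C/[S+](C)[O-])cc(=O)c2c1` follows from (butylcarbonyl)oxy in place of methyl on an aromatic carbon with (butylcarbonyl)oxy in place of methyl on an aromatic carbon. The steps of a 1.1-fold lower number from compound 2 to compound 3 (0.05 log units; within the scatter) and a 1.1-fold higher number from compound 1 to compound 3 (0.05 log units; within the scatter) and a 1.3-fold higher number from compound 1 to compound 2 (0.10 log units; within the scatter) bear on this change, since each swaps a group on an aromatic carbon, and all stay within the scatter. Within the data shown here, no measured compound carries (butylcarbonyl)oxy, so this is an extrapolation and the range is kept wide. No step beyond the scatter is expected in this assay for this change. The estimated 1.1-fold lower number from compound 3 to compound 4 (0.05 log units; within the scatter) is expected to be small. For compound 4 the expected value is 1500 nM (estimated range 700 nM to 3200 nM).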

Compound 4, half-maximal inhibitory concentration: 2400 nM
Estimate against measurement, compound 4: 1.6-fold (0.20 log units) below, within the range that was stated.
By their numbers in this assay, from the lowest: compounds 1, 3, 2 and 4 (each within the scatter of the next).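

Up to now, this position on the aromatic carbon had only carried hydrogen, methyl and ethoxy. In this assay, (butylcarbonyl)oxy, which brings a carbonyl and more heavy atoms than any of these, is accepted with no step beyond the scatter (a 1.4-fold higher number from compound 3 to compound 4 (0.15 log units; within the scatter); a 1.3-fold higher number from compound 2 to compound 4 (0.10 log units; within the scatter)). Placing butylcarbonyl instead of ethyl on the same oxygen also stays within the scatter (a 1.6-fold higher number from compound 1 to compound 4 (0.20 log units; within the scatter)), so all four compounds still form one level with no order among them. No measured evidence is available to account for this flat result.

As far as these compounds go, an amine or a carboxylic acid at this position, or a longer chain on the oxygen, remains open. Also open, from the compounds shown here alone, is whether any group here can move the number beyond the scatter.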